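The source may hold more compounds than are shown below. What is called first, only, known or untested is meant among the compounds shown, and "the series" means these compounds.

Compound 1 `CCCCCCCCCCCCNC(=O)[C@@H](NS(=O)(=O)c1ccc(C)cc1)[C@@H](C)O` gives 25800 nM in a functional assay on HepG2 cells (Homo sapiens) for cytotoxicity, read by MTT assay, with a stated time of 48 h; on this read-out higher numbers stand for weaker inhibition and lower numbers for stronger inhibition. Compound 2 `CCCCCCCCCCCCNC(=O)[C@@H](NS(=O)(=O)c1cccs1)[C@@H](C)O` differs from it by thiophen-2-yl in place of 4-methylphenyl on a sulfonyl sulfur; in this assay compound 2 gives 25900 nM, and the step is a 1.0-fold higher number from compound 1 to compound 2 (0.00 log units; within the scatter). Compound 3 `CCCCCCCCCCCCCCCCCCNC(=O)[C@@H](NS(=O)(=O)c1ccc(C)cc1)[C@@H](C)O` differs from compound 1 by hexyl in place of hydrogen on a saturated chain carbon, ten or more bonds along the chain from an amide-type nitrogen, so its core is the one with the octadecyl chain; in this assay compound 3 gives 75800 nM, a step of a 2.9-fold higher number from compound 1 to compound 3 (0.47 log units; beyond the scatter). Compound 4 `CCCCCCCCCCCCCCCCCCNC(=O)[C@@H](NS(=O)(=O)c1cccs1)[C@@H](C)O` has not been measured. It differs from compound 3 by thiophen-2-yl in place of 4-methylphenyl on a sulfonyl sulfur, the same change that leads from compound 1 to compound 2, made here on the core of compound 3. Because a 1.0-fold higher number from compound 1 to compound 2 (0.00 log units; within the scatter) lay within the scatter, the step from compound 3 to compound 4 is expected to be about a 1.0-fold higher number from compound 3 to compound 4 (0.00 log units; within the scatter). Compound 4 is thus estimated at 76000 nM in this assay, expected between 38000 nM and 150000 nM.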

Compound 4, half-maximal inhibitory concentration: > 200000 nM
Compound 4 ended at the assay's limit; the forecaster's own chance of this, stated with the estimate: 10%; middle value at least 2.6-fold (0.42 log units) away from the limit.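

In this assay compound 4 stands at > 200000 nM, which is a limit of the assay and not a number. Thiophen-2-yl in place of 4-methylphenyl gives an at least 2.6-fold higher number from compound 3 to compound 4 (0.42 log units; beyond the scatter) on the octadecyl core, so the neutral step seen on the dodecyl core did not simply carry over, though the size of any gap between the two steps stays unknown: the same change on two cores in this assay, a 1.0-fold higher number (0.00 log units; within the scatter) from compound 1 to compound 2 and an at least 2.6-fold higher number (0.42 log units; beyond the scatter) from compound 3 to compound 4; the limit leaves it open whether they differ. The longer chain gives an at least 7.7-fold higher number from compound 2 to compound 4 (0.88 log units; beyond the scatter) with the thiophen-2-yl group in place, and this comparison is equally unsettled: the same change on two cores in this assay, a 2.9-fold higher number (0.47 log units; beyond the scatter) from compound 1 to compound 3 and an at least 7.7-fold higher number (0.88 log units; beyond the scatter) from compound 2 to compound 4; the limit leaves it open whether they differ.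

The compounds shown leave open where between dodecyl and octadecyl the effect of the sulfonyl group might appear, for instance with a tetradecyl chain. They also leave open whether a furan-2-yl or plain phenyl group on the sulfonyl sulfur would behave like thiophen-2-yl on the octadecyl core.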